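The source may report more compounds than this note shows. Statements on the series, on what has been measured and on what is new or still open speak of the compounds shown alone.

Working notes on the series.

Among the compounds with values here, compound 3 `CCCCCCCCCCCCNC[C@@H]1OC[C@H](N)[C@@H]1O` gives 5870 nM in a functional assay on A549 cells (Homo sapiens) for antiproliferative activity, read by MTT assay, with a stated time of 72 h (a lower number here means a stronger inhibitor, a higher number a weaker inhibitor), the lowest of the three numbers measured so far. Compound 1 `CCCCCCCCCCCNC[C@@H]1OC[C@H](N)[C@H]1O` gives 9650 nM, a gap to compound 3 that lies within the scatter, so no order between the two can be claimed. Compound 2 `CCCCCCCCCCNC[C@@H]1OC[C@H](N)[C@@H]1O` gives 47800 nM, and the step of an 8.1-fold lower number from compound 2 to compound 3 (0.91 log units; beyond the scatter) is the only one in hand that is beyond the scatter.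

Compound 4 `CCCCCCCCCCCNC[C@@H]1OC[C@H](N)[C@@H]1O` is not yet measured. It differs from compound 3 as follows: hydrogen in place of methyl on a saturated chain carbon, ten or more bonds along the chain from an amine nitrogen. This is the same kind of change as the measured step, run in the opposite direction and cut at a smaller group: the measured step adds ethyl where the present change removes methyl. The measured step went an 8.1-fold lower number from compound 2 to compound 3 (0.91 log units; beyond the scatter), so the expectation for compound 4 is a weaker number than compound 3, but by a smaller margin, since only part of that difference is reversed. Compound 1 differs from compound 4 only elsewhere on the core and gives a number near compound 3, which tempers the expected loss.

For compound 4 the expected value is 14000 nM, range 6000 nM to 35000 nM, that is a step of a 2.4-fold higher number from compound 3 to compound 4 (0.38 log units; beyond the scatter) weaker than compound 3.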

Compound 4, half-maximal inhibitory concentration: 11100 nM
For compound 4 the middle estimate is 1.3-fold (0.10 log units) above the measured one; the measured number falls inside the stated range.
By their numbers in this assay, from the lowest: compounds 3, 1 and 4 (each within the scatter of the next); then compound 2.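

Shortening the chain from compound 3 gives, in this assay, a 1.9-fold higher number from compound 3 to compound 4 (0.28 log units; within the scatter), so removing this one methyl, on a saturated chain carbon, gives no readable change. Within the data shown here, the same kind of change at the next chain length does register, with a 4.3-fold lower number from compound 2 to compound 4 (0.63 log units; beyond the scatter), so the single added methyl on compound 2 already clears the scatter, while a further one on compound 4 does not. The third new step, a 1.2-fold higher number from compound 1 to compound 4 (0.06 log units; within the scatter), stays within the scatter, so the stereocentre at a saturated ring carbon separates nothing at this chain length, and the pair isolates that one feature: the fact that compounds 1 and 4 differ only in the configuration as drawn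

Going by these compounds, whether a longer chain than that of compound 3 would lower the number further or leave it level remains open. Also open, on these data alone, are whether the configuration matters with the shorter chain of compound 2 or the longer chain of compound 3, and whether a chain ending in a phenyl ring or a carboxylic acid would follow the same trend.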